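The compounds below may be only part of what the source reports. "The series", "measured", "known", "first", "only" and "open" are said of these compounds alone.

Compound 1 (`NC(=S)Nc1cccc(OCCCCCc2ccccc2)c1`) gives (22000 nM)
Compound 2 (`NC(=S)Nc1cccc(OCCCCCOc2ccc(Br)cc2)c1`) gives (19000 nM)
Compound 3 (`NC(=S)Nc1cccc(OCCCCCOc2ccc(N3CCCCC3)cc2)c1`) has not yet been measured

Both measured compounds were read in an ADME assay on Ava5 cells (Homo sapiens) for cytotoxicity (a lower number here means that less compound is tolerated, a higher number that more compound is tolerated), as a half-maximal cytotoxic concentration. Compound 2 stands at 19000 nM and lies within the scatter of compound 1 (22000 nM), so the two cannot be ranked.

The change now in question is piperidin-1-yl in place of bromo on an aromatic carbon and it leads to compound 3, with piperidin-1-yl in place of bromo on an aromatic carbon, para to a large group. Within the data shown here, no measured compound carries piperidin-1-yl, and no measured step touches this place directly. The nearest evidence is a 1.2-fold lower number from compound 1 to compound 2 (0.06 log units; within the scatter) and it concerns the replacement of phenyl by 4-bromophenoxy on a saturated chain carbon. On that single step, no change beyond the scatter is expected in this assay and no firm direction can be given. The expected step is a 1.1-fold lower number from compound 2 to compound 3 (0.05 log units; within the scatter) and this estimate stays within the scatter. Compound 3 is estimated at 17000 nM with an expected range of 7000 nM to 40000 nM as its limits.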

Compound 3, half-maximal cytotoxic concentration: 12000 nM
Compound 3: the middle estimate sits 1.4-fold (0.15 log units) above what was measured; low and high end bracket the measured number.
By their numbers in this assay, from the lowest: compounds 3, 2 and 1 (each within the scatter of the next).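

In this assay, piperidin-1-yl in place of bromo on an aromatic carbon, para to a large group, gives a 1.6-fold lower number from compound 2 to compound 3 (0.20 log units; within the scatter), and this is the only reading shown at this position, since the earlier step concerned a saturated chain carbon. It shows that a single bromine atom can give way here to a six-membered non-aromatic ring of 6 heavy atoms, with 1 hydrogen-bond acceptor, without a step beyond the scatter, so that this much larger group does not separate the two compounds in this read-out. No independent measurement bears on what lies behind this small step.

What the compounds shown leave open is whether any group at this aromatic carbon can move the number beyond the scatter, for instance an open-chain amine such as dimethylamino, a morpholine ring or a carboxylic acid. Since one step is a thin basis, they also leave open whether piperidin-1-yl would read the same way on a longer chain or a shorter one between the two oxygens.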